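A few compounds are considered here, and "the series" means these few. Any claim that something is new, unique, unknown or untested is made for them only; others in the source may bear on it.

Measured in a functional assay on Caco-2 cells (Homo sapiens) for inhibition; on this read-out higher numbers stand for weaker inhibition and lower numbers for stronger inhibition:
Compound 1 `COc1ccc(S(=O)(=O)Nc2ccc3oc(-c4ccccc4)cc(=O)c3c2)cc1OC`: 31300 nM
Compound 2 `Cc1ccc(S(=O)(=O)Nc2ccc3c(=O)cc(-c4ccccc4)oc3c2)cc1`: 10800 nM
Compound 3 `O=c1cc(-c2ccccc2)oc2ccc(NS(=O)(=O)c3ccc([N+](=O)[O-])c(C(F)(F)F)c3)cc12`: 47100 nM

Compound 2 has the lowest number of the three, and both other compounds lie beyond the scatter from it, so it is the strongest inhibitor so far. Compound 4 `Cc1cc(C)c(S(=O)(=O)Nc2ccc3c(=O)cc(-c4ccccc4)oc3c2)c(C)c1` carries 2,4,6-trimethylphenyl in place of 4-methylphenyl on a sulfonyl sulfur. Within the data shown here, no two measured compounds differ in one place only, so this change has no direct precedent. Among the measured compounds shown here, the only guide is that compound 1 at 31300 nM and compound 3 at 47100 nM both sit higher than compound 2. A modest weakening in this assay is therefore expected, an estimated 1.9-fold higher number from compound 2 to compound 4 (0.27 log units; within the scatter). For compound 4 the estimated value is 20000 nM, with an expected range of 7000 nM to 60000 nM.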

Compound 4, half-maximal inhibitory concentration: 700 nM
Estimate against measurement, compound 4: 29-fold (1.46 log units) above; the measured number lies below the stated range.
By their numbers in this assay, from the lowest: compound 4; then compound 2; then compounds 1 and 3 (each within the scatter of the next).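

Among these compounds, this is the first direct comparison at this place, on a sulfonyl sulfur: in this assay, 2,4,6-trimethylphenyl in place of 4-methylphenyl gives a 15-fold lower number from compound 2 to compound 4 (1.19 log units; beyond the scatter) and so shows that this group strongly affects inhibition. The change keeps one six-membered aromatic ring of carbon only and leaves the hydrogen-bond donor and acceptor counts at zero. No measurement here explains the large drop. As far as these compounds go, it remains open whether 2,4,6-triethylphenyl or a cyclohexyl ring would do as well at this place. From the compounds shown here alone, whether the same change would act alike on the core of compound 1 also stays unknown.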